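The compounds below may be only part of what the source reports. "The series", "measured", "known", "first", "only" and "open" are said of these compounds alone.

The study begins with compound 1 `Fc1cc(Cl)ccc1-c1ccc(Cn2nnc3ccccc32)cn1`. In an ADME assay on microsomes from liver (Rattus norvegicus, strain Wistar) for metabolic stability, tested at 2.5 uM (a higher number here means faster removal of the compound, a lower number slower removal), compound 1 gives 0.8 mL/min/g. Two close analogues accompany it: compound 2 `Clc1ccc(-c2ccc(Cn3nnc4ccccc43)cn2)cc1`, which in this assay gives 1 mL/min/g, and compound 3 `Fc1ccc2nnn(Cc3ccc(-c4ccc(Cl)cc4F)nc3)c2c1`, which in this assay gives 1 mL/min/g. Compound 1 holds the lowest of these three numbers, yet both neighbours lie within the scatter of it: a 1.3-fold higher number from compound 1 to compound 2 (0.10 log units; within the scatter) and a 1.3-fold higher number from compound 1 to compound 3 (0.10 log units; within the scatter).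

The next compound is compound 4 `N#Cc1cccc2c1nnn2Cc1ccc(-c2ccc(Cl)cc2F)nc1`. It differs from compound 1 in one place: cyano in place of hydrogen on an aromatic carbon. Within the data shown here, no measured step introduces a cyano group, so the two steps that bear on it are only loose guides: each swapped a fluoro for hydrogen on an aromatic carbon, or the reverse, and each stayed within the scatter. Since the change from compound 1 to compound 3 on the fused system of two rings stayed within the scatter, compound 4 is expected to stay close to compound 1 as well, with the estimated step of no change at the digits printed from compound 1 to compound 4 (within the scatter). Compound 4 is therefore estimated at 0.8 mL/min/g, within a range from 0.4 mL/min/g to 1.6 mL/min/g.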

Compound 4, intrinsic clearance in a liver preparation (reported as CLH), per the amount of preparation that the assay uses: 0.1 mL/min/g
Compound 4: the middle estimate sits 8.0-fold (0.90 log units) above what was measured; measured number outside the range, below it.
By their numbers in this assay, from the lowest: compound 4; then compounds 1, 2 and 3 (each within the scatter of the next).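

In this assay, the fused system of two rings proves responsive at this carbon, ortho to a fused ring and meta to a fused ring: cyano in place of hydrogen there gives an 8.0-fold lower number from compound 1 to compound 4 (0.90 log units; beyond the scatter). Among these compounds, the only earlier change on the fused system, fluoro in place of hydrogen on a different carbon, gave a 1.3-fold higher number from compound 1 to compound 3 (0.10 log units; within the scatter), so that step did not show that a single substituent on this ring could move the number beyond the scatter. No measurement at hand accounts for the step.

Since the cyano and fluoro groups sit on different carbons, the compounds shown cannot separate the effect of the group from that of its place. Going by these compounds, whether a methyl group, a methoxy group or an amide on the same carbon would also lower the number remains open.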